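The compounds below may be only part of what the source reports. "The series", "measured", "known", "first", "only" and "open" are said of these compounds alone.

Compound 1, `O=C1C(Nc2ccccc2)=CC(=O)c2c1nc1n2[C@H]2OC[C@@H](O)[C@H]2OC1`, carries an anilino group on its core. In a functional assay on MCF7 cells (Homo sapiens) for inhibition, read by sulforhodamine B assay (a higher number here means a weaker inhibitor, a lower number a stronger inhibitor), compound 1 gives only > 4000 nM, which is a limit of the assay and not a number. For the measured compounds named here, compound 2, `Cc1ccc(NC2=CC(=O)c3nc4n(c3C2=O)[C@H]2OC[C@@H](O)[C@H]2OC4)cc1C`, is the one member of this set with a measured number: in this assay compound 2 gives 2080 nM. Compound 3, `O=C1C=C(Nc2ccccc2)C(=O)c2c1nc1n2[C@H]2OC[C@@H](O)[C@H]2OC1`, in this assay gives > 4000 nM, again a limit of the assay rather than a number. Going by the values given here, the only measured step, an at least 1.9-fold higher number from compound 2 to compound 3 (0.28 log units; that floor lies within the scatter), exchanges phenyl for 3,4-dimethylphenyl on an amine nitrogen and ends at the limit of > 4000 nM in this assay, at which 2 of the 3 values shown sit, so it sets no clear size. Compound 4, `CCCN(CCC)C1=CC(=O)c2c(nc3n2[C@H]2OC[C@@H](O)[C@H]2OC3)C1=O`, differs from compound 1 by dipropylamino in place of anilino on a double-bonded ring carbon. Among the compounds with values here, no measured step exchanges an anilino group for a dialkylamino group, so the step from compound 1 to compound 4 has no direct precedent. Since compound 1 already sits at > 4000 nM, compound 4 is expected to remain weak, with an estimated 6000 nM (from 2000 nM to 20000 nM). The expected step is therefore a step that the limit leaves unreadable from compound 1 to compound 4, most likely ending in a limit again.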

Compound 4, half-maximal inhibitory concentration: > 16000 nM
Compound 4 was reported as a limit; the forecaster's own chance of this, stated with the estimate: 70%; at least 2.6-fold (0.42 log units) between middle value and limit.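

Compound 1 and compound 4 both stand only as limits of the assay in this assay, so no step can be read between them. The compounds shown leave open how anilino and dipropylamino compare on the shared core, since neither yields a number there.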